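This account rests on a few compounds, and the source may have more. Where it says the series, first, only, none or still open, it means among the compounds named here.

Compound 2 `COc1ccc([C@H]2CC(=O)N(c3ccccc3)C2)cc1OC1CCCC1` is the point of departure. In a functional assay on HEK293 cells (Homo sapiens) for cytotoxicity (a higher number here means that more compound is tolerated, a lower number that less compound is tolerated), compound 2 gives > 10000 nM, which is a limit of the assay rather than a measured number. Compound 1 `COc1ccc([C@H]2CC(=O)N(Cc3cccc(C#N)c3)C2)cc1OC1CCCC1` gives > 10000 nM in this assay, also a limit. Compound 3 `COc1ccc([C@H]2CC(=O)N(c3ccccc3N)C2)cc1OC1CCCC1` gives > 10000 nM in this assay, again a limit. All three values sit at the same limit (the limit of > 10000 nM in this assay, at which 3 of the 3 values shown sit), so the step that the two limits leave unreadable from compound 1 to compound 2 cannot be read, nor can a step that the two limits leave unreadable from compound 1 to compound 3 or a step that the two limits leave unreadable from compound 2 to compound 3.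

Compound 4 `COc1ccc([C@H]2CC(=O)N(c3cccc(NC(=O)C(C)=O)c3)C2)cc1OC1CCCC1` differs from compound 2 by (acetylcarbonyl)amino in place of hydrogen on an aromatic carbon. Going by these compounds, the closest measured comparison is the step from compound 2 to compound 3, in which a group also replaces a hydrogen on an aromatic carbon, but with both ends at the limit its size stays unknown. No readable step is therefore available, and no change beyond the scatter is expected in this assay. Compound 4 is expected to give 15000 nM, with a range from 5000 nM to 50000 nM. The estimated step that the limit leaves unreadable from compound 2 to compound 4 is expected to leave compound 4 at or near the same limit.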

Compound 4, half-maximal cytotoxic concentration: > 10000 nM
Compound 4 ended at the assay's limit; the forecaster's own chance of this, stated with the estimate: 80%; the middle value does not contradict the limit.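

Compound 4 sits at the same limit as compound 2, so no new step can be read between compound 2 and compound 4: the limit of > 10000 nM in this assay, at which 4 of the 4 values shown sit. The compounds shown leave open how far each lies beyond that limit in this assay, and whether any of these changes alters how much compound is tolerated.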